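The compounds below may be only part of what the source reports. "The series", "measured", "known", "first", "only" and "open" are said of these compounds alone.

Measured so far in a functional assay on HepG2 cells (Homo sapiens) for cytotoxicity, read by MTT assay, with a stated time of 72 h; a higher number here means a weaker inhibitor, a lower number a stronger inhibitor:

- compound 1, `Cc1cc(=O)n(-c2ccc(F)cc2)nc1C(=O)Nc1ccc(Oc2ncnc3[nH]ccc23)cc1`, gives > 60000 nM.
- compound 2, `Cc1ccc(-n2nc(C(=O)Nc3ccc(Oc4ncnc5[nH]ccc45)cc3)c(C)cc2=O)cc1`, gives 7460 nM.
- compound 3, `Cc1cc(=O)n(-c2ccc(Br)cc2F)nc1C(=O)Nc1ccc(Oc2ncnc3[nH]ccc23)cc1`, gives 3660 nM.

The value of compound 1 is a limit of the assay, not a number: the limit of > 60000 nM in this assay, at which 1 of the 3 values shown sits. Compound 1 therefore stands at the weak end of what is shown, and only a floor of its potency is known.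

All three measured steps change the aryl group on the aromatic nitrogen of the shared core: an at least 8.0-fold lower number from compound 1 to compound 2 (0.90 log units; beyond the scatter), an at least 16-fold lower number from compound 1 to compound 3 (1.21 log units; beyond the scatter), and a 2.0-fold lower number from compound 2 to compound 3 (0.31 log units; beyond the scatter). None of them touches the other aromatic ring.

Compound 4, `Cc1cc(=O)n(-c2ccc(F)cc2)nc1C(=O)Nc1ccc(Oc2ncnc3[nH]ccc23)c(F)c1`, differs from compound 1 in exactly that other place: fluoro in place of hydrogen on an aromatic carbon. No measured step covers a substitution on this ring, so nothing shown bears directly on the change, and no step beyond the scatter is expected in either direction in this assay. Since compound 1 is known only as a limit, the most likely outcome is that compound 4 is also reported as a limit. The estimate for compound 4 is 70000 nM, with a range of 20000 nM to 250000 nM, which means an expected step that the limit leaves unreadable from compound 1 to compound 4.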

Compound 4, half-maximal inhibitory concentration: 12900 nM
Estimate against measurement, compound 4: 5.4-fold (0.73 log units) above, outside the stated range (below it).
By their numbers in this assay, from the lowest: compound 3; then compounds 2 and 4 (each within the scatter of the next). At a limit, above all of these: compound 1.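

Substitution on the aromatic ring that the earlier steps left untouched also moves the number in this assay: fluoro in place of hydrogen, ortho to a large group and meta to a large group, gives an at least 4.6-fold lower number from compound 1 to compound 4 (0.66 log units; beyond the scatter). A change of a single heavy atom on this ring thus reaches beyond the scatter, so the aryl group on the aromatic nitrogen is no longer the only place shown to shift this read-out. Compound 1 is reported only as a limit, so the printed step is a minimum and its true size cannot be read: the limit of > 60000 nM in this assay, at which 1 of the 4 values shown sits.

On these data alone, it remains open whether this shift is specific to fluoro or would follow from other substituents at the same carbon; a chloro, methoxy or amine group there would separate these cases. As far as these compounds go, it also remains open whether fluoro on this ring would shift the number in the same way when combined with the 4-methylphenyl group of compound 2 or the 4-bromo-2-fluorophenyl group of compound 3.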